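The compounds below may be only part of what the source reports. "The series", "measured", "known", "first", "only" and "open" are said of these compounds alone.

Measured so far:
compound 1, `Cc1ncc([N+](=O)[O-])n1CCOC(=O)c1cccc(Cl)c1`, gives 16300 nM in an assay for inhibition of beta-glucuronidase (Bos taurus), read by spectrophotometry, with a stated time of 30 min; a lower number here means a stronger inhibitor, a higher number a weaker inhibitor
compound 2, `Cc1ncc([N+](=O)[O-])n1CCOC(=O)c1cccc(F)c1`, gives 8100 nM in this assay

Among the measured compounds shown here, compound 2 holds the lowest of the two numbers, yet the only step measured, a 2.0-fold lower number from compound 1 to compound 2 (0.30 log units; within the scatter), stays within the scatter, so nothing separates the two compounds. Compound 3, `Cc1ncc([N+](=O)[O-])n1CCOC(=O)c1ccc(F)cc1`, differs from compound 2 by 4-fluorophenyl in place of 3-fluorophenyl on a carbonyl carbon. For the measured compounds named here, no measured step moves a group to a different place on the ring, so that change gives no guide, and the step of a 1.1-fold higher number from compound 2 to compound 3 (0.05 log units; within the scatter) is expected to stay within the scatter. Compound 3 is therefore estimated at 9000 nM in this assay, within a range from 3000 nM to 27000 nM.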

Compound 3, half-maximal inhibitory concentration: 12400 nM
Estimate against measurement, compound 3: 1.4-fold (0.14 log units) below, within the range that was stated.
By their numbers in this assay, from the lowest: compounds 2, 3 and 1 (each within the scatter of the next).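

Moving the fluorine, with 4-fluorophenyl in place of 3-fluorophenyl on the carbonyl carbon, gives a 1.5-fold higher number from compound 2 to compound 3 (0.18 log units; within the scatter) in this assay, so this change of place on the ring separates nothing. Changing the halogen and its place in one step, with 4-fluorophenyl in place of 3-chlorophenyl, gives a 1.3-fold lower number from compound 1 to compound 3 (0.12 log units; within the scatter) and leaves the picture the same. Nothing available explains these small differences.

All three halogen-bearing rings thus remain indistinguishable in this assay. Still open, from the compounds shown here alone, is whether a quite different group on the ring, such as an amine or a carboxylic acid, would move the number beyond the scatter.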